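Hydroxy to methoxy on the 3-hydroxyphenyl group of compound 1

A few compounds are considered here, and "the series" means these few. Any claim that something is new, unique, unknown or untested is made for them only; others in the source may bear on it.

In a functional assay on SF-268 cells (Homo sapiens) for antiproliferative activity, read by sulforhodamine B assay, with a stated time of 48 h (a higher number here means a weaker inhibitor, a lower number a stronger inhibitor), compound 1 `O=C(NCCCNc1cc(-c2cn(-c3ccccc3)nc2-c2cccc(O)c2)ccn1)Nc1ccc(F)cc1` gives 2610 nM. Among the compounds with values here, compound 2 `O=C(NCCCNc1cc(-c2cn(-c3ccccc3)nc2-c2cccc(O)c2)ccn1)Nc1cccc(C(F)(F)F)c1` gives 3260 nM, and these two values lie within the scatter of each other, so compound 1 stands level with the only other measured compound.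

The next compound, compound 3 `COc1cccc(-c2nn(-c3ccccc3)cc2-c2ccnc(NCCCNC(=O)Nc3ccc(F)cc3)c2)c1`, keeps the rest of compound 1 and changes 3-hydroxyphenyl to 3-methoxyphenyl: methyl in place of hydrogen on an oxygen on an aromatic ring. This places methyl in place of hydrogen on an oxygen on an aromatic ring.

Within the data shown here, only one measured step is available, a 1.2-fold higher number from compound 1 to compound 2 (0.10 log units; within the scatter). It concerns an amide-type nitrogen, not this oxygen, so it bears on the new change only indirectly. It shows that one substitution elsewhere on compound 1 left this assay within the scatter, but it gives no direction for hydroxy to methoxy.

Among the measured compounds shown here, no measured pair alters this oxygen, so no shift beyond the scatter can be forecast with confidence, and the range is kept wide. The expected step is a 1.3-fold higher number from compound 1 to compound 3 (0.11 log units; within the scatter), which is small and uncertain in direction.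

For compound 3 the estimated value is 3400 nM, with an expected range of 1300 nM to 9500 nM.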

Compound 3, half-maximal inhibitory concentration: 7080 nM
The estimate for compound 3 lay 2.1-fold (0.32 log units) below the measured number; the measured number falls inside the stated range.
By their numbers in this assay, from the lowest: compounds 1 and 2 (each within the scatter of the next); then compound 3.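

In this assay methyl in place of hydrogen on an oxygen on an aromatic ring gives a 2.7-fold higher number from compound 1 to compound 3 (0.43 log units; beyond the scatter) and so moves the number beyond the scatter. Within the data shown here, the one earlier step, a 1.2-fold higher number from compound 1 to compound 2 (0.10 log units; within the scatter) at an amide-type nitrogen, stayed within the scatter, so this oxygen is the first place where a single change gives a readable shift. The direction is now set for this one pair, with 4-fluorophenyl held constant: hydroxy gives the lower number and methoxy the higher, and nothing at hand bears on the reason for the rise.

From the compounds shown here alone, whether the same step holds with the 3-(trifluoromethyl)phenyl group of compound 2 remains open, and so does the question of whether the shift is specific to methyl or also follows from an ethyl group or a longer chain on this oxygen. Also open, going by these compounds, is how the series responds when an amine, a carboxylic acid or a fluorine stands in place of the hydroxy group on the phenyl ring.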